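Furan to Thiophene on a Shared Core

This account rests on a few compounds, and the source may have more. Where it says the series, first, only, none or still open, it means among the compounds named here.

Of the compounds shown here, two have been measured. Compound 1 `O=C(Nn1c(-c2cccc([N+](=O)[O-])c2)nc2c(-c3ccc(Cl)cc3)n[nH]c2c1=O)c1cccnc1` gives 15.1% in a functional assay on HT-29 cells (Homo sapiens) for cytotoxicity, read by sulforhodamine B assay, with a stated time of 2 days, tested at 100 uM; on this read-out higher numbers stand for more inhibition at the one concentration tested (going by the name of the read-out) and lower numbers for less inhibition. Compound 2 `O=C(Nn1c(-c2cccc([N+](=O)[O-])c2)nc2c(-c3ccco3)n[nH]c2c1=O)c1cccnc1` carries furan-2-yl in place of 4-chlorophenyl on an aromatic carbon, and in this assay compound 2 gives 11.7%. The step of a number 3.4 percentage points lower from compound 1 to compound 2 (within the scatter) lies within the scatter, so the two numbers cannot be told apart. Of the two numbers, compound 2 gives the lower one, but its distance from compound 1 is within the scatter.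

Compound 3 `O=C(Nn1c(-c2cccc([N+](=O)[O-])c2)nc2c(-c3cccs3)n[nH]c2c1=O)c1cccnc1` differs from compound 2 by thiophen-2-yl in place of furan-2-yl on an aromatic carbon. Within the data shown here, the only measured step, a number 3.4 percentage points lower from compound 1 to compound 2 (within the scatter), exchanged one aromatic group for another on the same aromatic carbon and stayed within the scatter; no step that exchanges furan-2-yl for thiophen-2-yl has yet been measured, so nothing argues for a larger effect here. On that basis compound 3 is expected to show a step of a number 1.3 percentage points higher from compound 2 to compound 3 (within the scatter) that does not go beyond the scatter in this assay. Compound 3 is therefore estimated at 13%, with a range from 0% to 30%.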

Compound 3, a percentage reported as inhibition, at one concentration (the size of the read-out at that concentration, not a potency): 3.9%
For compound 3 the middle estimate is 9.1 percentage points above the measured one; low and high end bracket the measured number.
By their numbers in this assay, from the lowest: compounds 3, 2 and 1 (each within the scatter of the next, the first and the last beyond it).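

The exchange of furan-2-yl for thiophen-2-yl, a number 7.8 percentage points lower from compound 2 to compound 3 (within the scatter) in this assay, cannot be told apart from no change, so swapping oxygen for sulfur in this five-membered aromatic ring shows no readable effect at this position. Among these compounds, the other new step, a number 11.2 percentage points lower from compound 1 to compound 3 (beyond the scatter), is the first at this aromatic carbon to go beyond the scatter, and it shows that the group placed here can shift the number, if only modestly. This does not amount to a general contrast between 4-chlorophenyl and five-membered rings, as compound 2 goes against it by lying within the scatter of both compound 1 and compound 3, and no available evidence accounts for the gap.

Going by these compounds, all three compounds carry an aromatic ring on this carbon, so it remains open how an amine, a carboxylic acid or a longer alkyl chain would read there. Each number also comes from a single concentration, which leaves open how the compounds would compare in potency.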